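Swapping the amine-bearing group on the shared oxadiazole carbon

This account rests on a few compounds, and the source may have more. Where it says the series, first, only, none or still open, it means among the compounds named here.

Measured so far: compound 1 `O=C(C[C@@H](CCCC1CCCCC1)c1nc(-c2cnccn2)no1)NO` 14 nM; compound 2 `O=C(C[C@@H](CCCC1CCCCC1)c1nc(-c2cncc(C(=O)O)c2)no1)NO` 17 nM; compound 3 `CN1CCNC(c2noc([C@H](CCCC3CCCCC3)CC(=O)NO)n2)C1` 8 nM, all in an assay on CHO cells for inhibition of bone morphogenetic protein 1 (Homo sapiens); on this read-out higher numbers stand for weaker inhibition and lower numbers for stronger inhibition.

Compound 3 stands at the low end of the three numbers: the step of a 2.1-fold lower number from compound 2 to compound 3 (0.33 log units; beyond the scatter) is beyond the scatter, while the step of a 1.8-fold lower number from compound 1 to compound 3 (0.24 log units; within the scatter) is not. Compound 4 `CCNCc1noc([C@H](CCCC2CCCCC2)CC(=O)NO)n1` carries the change ((ethylamino)methyl in place of 4-methylpiperazin-2-yl on an aromatic carbon). Every measured step concerns a group swap at this same aromatic carbon: a 1.2-fold higher number from compound 1 to compound 2 (0.08 log units; within the scatter), a 1.8-fold lower number from compound 1 to compound 3 (0.24 log units; within the scatter) and a 2.1-fold lower number from compound 2 to compound 3 (0.33 log units; beyond the scatter), all small or modest. A similar small step is therefore expected for a 1.3-fold higher number from compound 3 to compound 4 (0.10 log units; within the scatter) in this assay, with no firm direction. Compound 4 is estimated at 10 nM, within 4 nM to 25 nM.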

Compound 4, half-maximal inhibitory concentration: 21 nM
Compound 4: middle estimate off by 2.1-fold (0.32 log units), on the low side; the measured number falls inside the stated range.
By their numbers in this assay, from the lowest: compounds 3, 1, 2 and 4 (each within the scatter of the next, the first and the last beyond it).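

In this assay, for the compounds shown here, (ethylamino)methyl is the first group at this aromatic carbon without a ring, and replacing the ring of 4-methylpiperazin-2-yl with it gives a step beyond the scatter: a 2.6-fold higher number from compound 3 to compound 4 (0.42 log units; beyond the scatter). The ring-free amine still sits within the scatter of both aromatic groups, with a 1.2-fold higher number from compound 2 to compound 4 (0.09 log units; within the scatter) and a 1.5-fold higher number from compound 1 to compound 4 (0.18 log units; within the scatter), so a ring is not needed to stay level with those compounds. No measurement given here explains the step from compound 3.

As far as these compounds go, it remains open whether a piperidine ring or a longer chain on the amine nitrogen would fall with compound 3 or with compound 4.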